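The compounds below may be only part of what the source reports. "The series", "measured", "known", "first", "only" and "open" are said of these compounds alone.

Three compounds built on one shared core were measured in an assay on isolated protein with Bile acid receptor (Homo sapiens) as the target; a higher number here means that more compound is needed for the effect, a lower number that less compound is needed. Compound 1 `COC(=O)/C=C/c1cccc(N(Cc2ccc(/C=C/c3ccccn3)cc2)C(=O)C2CCCCC2)c1` gives 309 nM in this assay. Compound 2 `COC(=O)/C=C/c1cccc(N(Cc2ccc(/C=C/c3scnc3C)cc2)C(=O)C2CCCCC2)c1` gives 227 nM in this assay. Compound 3 `COC(=O)/C=C/c1cccc(N(Cc2ccc(-c3cccc(C)c3)cc2)C(=O)C2CCCCC2)c1` gives 109 nM in this assay, the lowest number of the three, with compound 2 nearest to it and compound 1 furthest away. The steps that link them are a 1.4-fold lower number from compound 1 to compound 2 (0.13 log units; within the scatter), a 2.8-fold lower number from compound 1 to compound 3 (0.45 log units; beyond the scatter) and a 2.1-fold lower number from compound 2 to compound 3 (0.32 log units; beyond the scatter).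

Compound 4 `COC(=O)/C=C/c1cccc(N(Cc2ccc(-c3ccc(C(C)(C)C)cc3)cc2)C(=O)C2CCCCC2)c1` has not yet been measured. It differs from compound 3 in one place: 4-(tert-butyl)phenyl in place of 3-methylphenyl on an aromatic carbon. Among the compounds with values here, none of the measured steps touches the substituent on a directly attached phenyl; the two steps that involve that phenyl at all, a 2.8-fold lower number from compound 1 to compound 3 (0.45 log units; beyond the scatter) and a 2.1-fold lower number from compound 2 to compound 3 (0.32 log units; beyond the scatter), bring it in as a replacement for a 2-(pyridin-2-yl)ethenyl or a 2-(4-methyl-1,3-thiazol-5-yl)ethenyl group, and both were modest. The data thus give no direct guide to exchanging 3-methylphenyl for 4-(tert-butyl)phenyl, so the step expected in this assay is a 1.1-fold higher number from compound 3 to compound 4 (0.04 log units; within the scatter), none beyond the scatter. For compound 4 the estimate in this assay is 120 nM, within a range from 45 nM to 320 nM.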

Compound 4, half-maximal effective concentration: 132 nM
Compound 4: middle estimate off by 1.1-fold (0.04 log units), on the low side; the range from low to high includes it.
By their numbers in this assay, from the lowest: compounds 3, 4, 2 and 1 (each within the scatter of the next, the first and the last beyond it).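

Within the data shown here, on this aromatic carbon, compound 4 gives the first exchange of one directly attached phenyl group for another: in this assay, 4-(tert-butyl)phenyl in place of 3-methylphenyl gives a 1.2-fold higher number from compound 3 to compound 4 (0.08 log units; within the scatter), so the number stays within the scatter although the group entering has 10 heavy atoms and the group leaving has 7. Set against the two ethenyl groups, the 4-(tert-butyl)phenyl group gives a 1.7-fold lower number from compound 2 to compound 4 (0.24 log units; within the scatter) and a 2.3-fold lower number from compound 1 to compound 4 (0.37 log units; beyond the scatter), so only its step from the 2-(pyridin-2-yl)ethenyl group lies beyond the scatter, whereas 3-methylphenyl gave steps beyond the scatter from both ethenyl groups. No measurement at hand bears on the reason for this result.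

This one step alters both the substituent and where it sits on the phenyl, so the compounds shown leave open what each of these changes does alone, which 4-methylphenyl or 3-(tert-butyl)phenyl at this carbon could help to separate. They also leave open whether a phenyl carrying an amine or a carboxylic acid would stay within the scatter of compound 3 and compound 4 in this assay.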